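The compounds below may be only part of what the source reports. "The series", "measured", "known", "first", "only" and "open" are said of these compounds alone.

Working notes on the series. In an ADME assay on HEK293 cells (Homo sapiens) for cytotoxicity, read by reporter gene assay and resazurin assay, with a stated time of 48 h (a higher number here means that more compound is tolerated, a lower number that less compound is tolerated), compound 1 `COc1c(Br)cc(Br)cc1C(=O)Nc1ccc(Sc2nc3ccccc3s2)c(Cl)c1` gives > 100000 nM, which is a limit. Compound 2 `O=C(Nc1ccc(Sc2nc3ccccc3s2)c(Cl)c1)c1cccc(Br)c1` gives > 100000 nM, also a limit. Compound 3 `COc1c(Br)cccc1C(=O)Nc1ccc(Sc2nc3ccccc3s2)c(Cl)c1` gives > 100000 nM, again a limit. Compound 3 therefore has no number of its own, and the same holds for the other two, all sitting at the limit of > 100000 nM in this assay, at which 3 of the 3 values shown sit.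

Compound 4 `O=C(Nc1ccc(Sc2nc3ccccc3s2)c(Cl)c1)c1cc(Br)ccc1O` differs from compound 3 by a group of 8 heavy atoms (6 carbon, 1 oxygen, 1 bromine; one six-membered aromatic ring of carbon only) in place of a group of 9 heavy atoms (7 carbon, 1 oxygen, 1 bromine; one six-membered aromatic ring of carbon only), on a carbonyl carbon: 5-bromo-2-hydroxyphenyl enters on a carbonyl carbon whose other neighbour is an amide-type nitrogen.

The measured steps touch this same group, but none gives a size: a step that the two limits leave unreadable from compound 1 to compound 3, a step that the two limits leave unreadable from compound 2 to compound 3 and a step that the two limits leave unreadable from compound 1 to compound 2. None of them brings in 5-bromo-2-hydroxyphenyl, so no size carries over, and the expectation is only a weak one. The expected change is an at least 2.5-fold lower number from compound 3 to compound 4 (0.39 log units; beyond the scatter), in the direction of less compound tolerated, and a further limit remains quite possible. For compound 4 the estimate is 40000 nM, with an expected range of 8000 nM to 100000 nM.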

Compound 4, half-maximal cytotoxic concentration: 45000 nM
Beside the measured number, compound 4's estimate is 1.1-fold (0.05 log units) below it; the range from low to high includes it.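

In this assay, among the compounds shown here, the entry of 5-bromo-2-hydroxyphenyl on the carbonyl carbon gives an at least 2.2-fold lower number from compound 3 to compound 4 (0.34 log units; beyond the scatter) as the first readable step at this position, while the steps among compounds 1, 2 and 3 cannot be read. The added hydroxy gives an at least 2.2-fold lower number from compound 2 to compound 4 (0.34 log units; beyond the scatter) and the change from the dibromo-bearing group of compound 1 gives an at least 2.2-fold lower number from compound 1 to compound 4 (0.34 log units; beyond the scatter) with each size a minimum only. Compound 4 alone carries a number of its own, and the other three stay at a limit: the limit of > 100000 nM in this assay, at which 3 of the 4 values shown sit.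

The compounds shown leave open how large these steps really are, since each starts from a limit. They also leave open whether the hydroxy can be replaced by an amine or a carboxylic acid on the same ring, or whether it still lowers the number without the bromine.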